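One Side-Chain Swap and an Expected Drop

The source may hold more compounds than are shown below. What is called first, only, known or untested is meant among the compounds shown, and "the series" means these compounds.

Among the measured compounds shown here, in a toxicity assay on L02 cells (Homo sapiens) for cytotoxicity, read by MTT assay, with a stated time of 72 h (a lower number here means a stronger inhibitor, a higher number a weaker inhibitor), compound 2 (`O=C1c2c[n+]([O-])c3ccccc3c2C(=O)c2c1c1ccccc1n2CCN1CCCCC1`) gives 1050 nM and so has the higher of the only two numbers known, which makes it the weaker inhibitor of the pair. Compound 1 (`CN1CCN(CCCCn2c3c(c4ccccc42)C(=O)c2c[n+]([O-])c4ccccc4c2C3=O)CC1`) gives 80 nM in this assay and shares its core.

Compound 3 (`CN(C)CCCCn1c2c(c3ccccc31)C(=O)c1c[n+]([O-])c3ccccc3c1C2=O`) differs from compound 2 in one place (2-(dimethylamino)ethyl in place of piperidin-1-yl on a saturated chain carbon, two bonds along the chain from an aromatic nitrogen): 2-(dimethylamino)ethyl in place of piperidin-1-yl on a saturated chain carbon, two bonds along the chain from an aromatic nitrogen.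

For the measured compounds named here, the only measured step touches that same place (a 13-fold higher number from compound 1 to compound 2 (1.12 log units; beyond the scatter)) and is large, well beyond the scatter. There, piperidin-1-yl replaced 2-(4-methylpiperazin-1-yl)ethyl, so the new group in compound 3 undoes that swap in part, bringing back an ethyl link that ends in an amine. One step is slim evidence, and the dimethylamino end has no ring, unlike the methylpiperazine end of compound 1. The expected change is therefore only part of that distance, toward a lower number: a 4.2-fold lower number from compound 2 to compound 3 (0.62 log units; beyond the scatter) is the estimated step. For compound 3 the estimated value is 250 nM with an expected range from 70 nM to 900 nM in this test.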

Compound 3, half-maximal inhibitory concentration: 300 nM
Compound 3: middle estimate off by 1.2-fold (0.08 log units), on the low side, within the range that was stated.
By their numbers in this assay, from the lowest: compound 1; then compound 3; then compound 2.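

Compound 3 keeps the butyl chain of compound 1 and changes only its end, and a 3.8-fold higher number from compound 1 to compound 3 (0.57 log units; beyond the scatter) in this assay. With the chain held, then, the end group alone moves the number: dimethylamino sits on the weaker side of 4-methylpiperazin-1-yl. The step of a 3.5-fold lower number from compound 2 to compound 3 (0.54 log units; beyond the scatter) adds that a ring on the end of the chain is not needed for a lower number, since 4-(dimethylamino)butyl has no ring and still beats 2-(piperidin-1-yl)ethyl, although that step changes chain length and end group together, as the earlier large step did. Nothing shown here gives a measured reason for either step.

A 4-(piperidin-1-yl)butyl group would carry the ring of compound 2 on the chain of compound 3, and only such a compound could split the step from compound 2 into a part for the chain and a part for the end group. Also open, going by these compounds, is how a morpholin-4-yl end on the same butyl chain would compare with the dimethylamino and 4-methylpiperazin-1-yl ends.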